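The compounds below may be only part of what the source reports. "The series", "measured", "known", "first", "only" and "open" are said of these compounds alone.

In a functional assay on MCF7 cells (Homo sapiens) for antiproliferative activity, read by MTT assay, with a stated time of 48 h (a lower number here means a stronger inhibitor, a higher number a weaker inhibitor), three compounds sharing one core have been measured so far. Compound 1 (`Cc1ccc(C(=O)/C=C/c2cc(Br)cc(Br)c2Oc2c([N+](=O)[O-])cc(C(F)(F)F)cc2[N+](=O)[O-])cc1`) gives 1.44 ug/mL and compound 2 (`Cc1ccc(C(=O)/C=C/c2cc(Cl)cc(Cl)c2Oc2c([N+](=O)[O-])cc(C(F)(F)F)cc2[N+](=O)[O-])cc1`) gives 0.7 ug/mL while compound 3 (`COc1ccc(C(=O)/C=C/c2cc(Cl)cc(Cl)c2Oc2c([N+](=O)[O-])cc(C(F)(F)F)cc2[N+](=O)[O-])cc1`) gives 2.69 ug/mL as its number. Among the compounds with values here, compound 3 thus lies within the scatter of compound 1 but stands apart from compound 2, with methoxy in place of methyl on an aromatic carbon giving a 3.8-fold higher number from compound 2 to compound 3 (0.58 log units; beyond the scatter) in the one measured step.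

Compound 4 (`COc1ccc(C(=O)/C=C/c2cccc(Cl)c2Oc2c([N+](=O)[O-])cc(C(F)(F)F)cc2[N+](=O)[O-])cc1`) departs from compound 3 by a single change (hydrogen in place of chloro on an aromatic carbon) with hydrogen in place of chloro on an aromatic carbon. Within the data shown here, no measured step removes a chloro group, so the data bear on this change only indirectly. Among the measured compounds shown here, the sole guide to size is the pair of compound 2 and compound 3 with a 3.8-fold higher number from compound 2 to compound 3 (0.58 log units; beyond the scatter) as its measure, and that step concerns a different group. In this assay a step no larger than that one is expected, most likely none beyond the scatter, with a slight lean toward a higher number. The estimate therefore means a 1.3-fold higher number from compound 3 to compound 4 (0.10 log units; within the scatter) as the expected step. For compound 4 the estimated value is 3.4 ug/mL with an expected range from 1.2 ug/mL to 9.5 ug/mL in this estimate.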

Compound 4, half-maximal inhibitory concentration: 1.83 ug/mL
Compound 4: middle estimate off by 1.9-fold (0.27 log units), on the high side; the range from low to high includes it.
By their numbers in this assay, from the lowest: compound 2; then compounds 1, 4 and 3 (each within the scatter of the next).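

In this assay, within the data shown here, hydrogen in place of chloro on the aromatic carbon meta to a 2-((4-methoxyphenyl)carbonyl)ethenyl group and para to a large group gives a 1.5-fold lower number from compound 3 to compound 4 (0.17 log units; within the scatter) as the first measured step at this position. The earlier compounds shown here all carry a halogen at this place, so they could not show that the chloro group there can give way to hydrogen with the result staying within the scatter in the methoxy series. No measured evidence accompanies this result to explain it.

The compounds shown leave open whether the same exchange would stay within the scatter with methyl in place of methoxy, as in compound 2, or at the place of the remaining chloro group. They also leave open how this position would respond to something other than a halogen or hydrogen, such as an amine, a carboxylic acid or a longer chain.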